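Amine swap on the alkoxy chain of a flavone series

The source may report more compounds than this note shows. Statements on the series, on what has been measured and on what is new or still open speak of the compounds shown alone.

Measured so far:
compound 1, `O=c1cc(-c2ccccc2)oc2cc(OCc3ccccc3)c(OCCCN3CCCC3)c(O)c12`, 4200 nM
compound 2, `CN1CCN(CCCCOc2c(O)cc3oc(-c4ccccc4)cc(=O)c3c2O)CC1`, 93700 nM
compound 3, `CN1CCN(CCCOc2c(OCc3ccccc3)cc3oc(-c4ccccc4)cc(=O)c3c2O)CC1`, 2400 nM

All three were read in a functional assay on HepG2 cells (Homo sapiens) for antiproliferative activity, read by MTT assay, with a stated time of 48 h; on this read-out lower numbers stand for stronger inhibition and higher numbers for weaker inhibition. Compound 1 and compound 3 share one core; compound 1 carries pyrrolidin-1-yl in place of 4-methylpiperazin-1-yl on a saturated chain carbon, three bonds along the chain from an oxygen on an aromatic ring, and the step of a 1.8-fold higher number from compound 3 to compound 1 (0.24 log units; within the scatter) lies within the scatter. Compound 2 gives the highest number of the three, with steps to compound 1 and to compound 3 both beyond the scatter. How the core of compound 2 differs from that of compound 3 is not broken down here.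

Compound 4, `O=c1cc(-c2ccccc2)oc2cc(O)c(OCCCCN3CCCC3)c(O)c12`, is not yet measured; it carries pyrrolidin-1-yl in place of 4-methylpiperazin-1-yl on a saturated chain carbon, four bonds along the chain from an oxygen on an aromatic ring. This is the same kind of change as from compound 3 to compound 1, not the same: there the place was three bonds along the chain from an oxygen on an aromatic ring, here it is four bonds. Because the step of a 1.8-fold higher number from compound 3 to compound 1 (0.24 log units; within the scatter) stayed within the scatter, the step from compound 2 to compound 4 is expected to be similar in size, a 1.3-fold higher number from compound 2 to compound 4 (0.11 log units; within the scatter). Compound 4 is therefore expected to give 120000 nM in this assay, estimated between 45000 nM and 320000 nM.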

Compound 4, half-maximal inhibitory concentration: > 100000 nM
Compound 4: only a limit was reported; the forecaster's own chance of this, stated with the estimate: 15%; the middle value does not contradict the limit.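

In this assay compound 4 gives > 100000 nM, which is a limit of the assay and not a number. The swap to pyrrolidin-1-yl from 4-methylpiperazin-1-yl on this core can therefore be read only as a floor, an at least 1.0-fold higher number from compound 2 to compound 4 (0.02 log units; that floor lies within the scatter), and whether the change carries over from one core to the other in the same size stays undecided: the same change on two cores in this assay, a 1.8-fold higher number (0.24 log units; within the scatter) from compound 3 to compound 1 and an at least 1.0-fold higher number (0.02 log units; that floor lies within the scatter) from compound 2 to compound 4; the limit leaves it open whether they differ The data give no actual size for the step on this core, only a reading that ends at the limit: the limit of > 100000 nM in this assay, at which 1 of the 4 values shown sits.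

Still open, as far as these compounds go, is how piperidin-1-yl or morpholin-4-yl would read in place of either amine on these chains. Also open, from the compounds shown here alone, is how a longer chain would read on either core.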